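This account rests on a few compounds, and the source may have more. Where it says the series, first, only, none or still open, it means among the compounds named here.

Measured compounds:
Compound 1 `Cn1nccc1-c1ccccc1NCC1=NCCN1`: in an in vitro functional assay on cells (Fibroblast) for agonist activity at Alpha-1D adrenergic receptor (Homo sapiens) (on this read-out higher numbers stand for an effect only at larger amounts of compound and lower numbers for an effect already at smaller amounts), compound 1 gives < 100000 nM, a limit of the assay and not a number.
Compound 2 `Cn1ccc(-c2ccccc2NCC2=NCCN2)n1`: in this assay compound 2 gives 15.9 nM.

Compound 2 holds the only number shown in this assay; the other value of the series sits at the limit (the limit of < 100000 nM in this assay, at which 1 of the 2 values shown sits). Among the compounds with values here, the step that the limit leaves unreadable from compound 1 to compound 2 therefore cannot be read in size, and it is the only measured step.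

Compound 3 `c1ccc(-c2cn[nH]c2)c(NCC2=NCCN2)c1` differs from compound 2 by 1H-pyrazol-4-yl in place of 1-methyl-1H-pyrazol-3-yl on an aromatic carbon. Within the data shown here, no measured step bears directly on this change, since the one recorded step, a step that the limit leaves unreadable from compound 1 to compound 2, concerns the position of the methyl-bearing pyrazole and not the removal of its methyl group, and its size is unreadable. The expectation for compound 3 in this assay rests only on compound 2 and its value 15.9 nM, with a wide range to cover the unreadable step. Compound 3 is estimated at 40 nM, between 8 nM and 300 nM, which is expected to mean a step of a 2.5-fold higher number from compound 2 to compound 3 (0.40 log units; beyond the scatter).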

Compound 3, half-maximal effective concentration: 20 nM
Beside the measured number, compound 3's estimate is 2.0-fold (0.30 log units) above it, and the stated range covers the measured number.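

In this assay, 1H-pyrazol-4-yl in place of 1-methyl-1H-pyrazol-3-yl gives a 1.3-fold higher number from compound 2 to compound 3 (0.10 log units; within the scatter), so the two groups cannot be told apart at this place on the aromatic carbon. Within the data shown here, the read-out therefore holds across a change from 6 heavy atoms, 0 hydrogen-bond donors and 2 hydrogen-bond acceptors to 5 heavy atoms, 1 hydrogen-bond donor and 1 hydrogen-bond acceptor, and the number of compound 2 is no longer the only one for a pyrazole group here. Compound 1, with 1-methyl-1H-pyrazol-5-yl, is the one compound that does not share this result, yet its steps to compound 2 and compound 3 cannot be read because it stands at a limit of the assay: the limit of < 100000 nM in this assay, at which 1 of the 3 values shown sits.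

Compound 3 differs from compound 2 both in the methyl group and in the pyrazole carbon that carries the bond, so these two changes remain unseparated, and 1-methyl-1H-pyrazol-4-yl or 1H-pyrazol-3-yl would be needed to pull them apart. Going by these compounds, whether the same place also accepts a group other than a pyrazole, such as a phenyl ring, an amine or a carboxylic acid, stays open.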